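The oxazole ketone series moves from aryl to amide

This account rests on a few compounds, and the source may have more. Where it says the series, first, only, none or still open, it means among the compounds named here.

Three compounds share one core and differ only in the group attached to the five-membered ring. In an assay (Rattus norvegicus) for inhibition of Fatty-acid amide hydrolase 1 (Homo sapiens) (a higher number here means a weaker inhibitor, a lower number a stronger inhibitor), compound 1 `O=C(CCCCCCc1ccccc1)c1ncc(-c2ccccc2F)o1` gives 110 nM, compound 2 `N#Cc1ccc(-c2cnc(C(=O)CCCCCCc3ccccc3)o2)cc1` gives 40 nM, and compound 3 `Cc1cccnc1-c1cnc(C(=O)CCCCCCc2ccccc2)o1` gives 15 nM. Compound 3 stands at the lowest number of the three: the steps of a 7.3-fold lower number from compound 1 to compound 3 (0.87 log units; beyond the scatter) and a 2.7-fold lower number from compound 2 to compound 3 (0.43 log units; beyond the scatter) are both beyond the scatter, as is a 2.8-fold lower number from compound 1 to compound 2 (0.44 log units; beyond the scatter).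

Compound 4 `CN(C)C(=O)c1cnc(C(=O)CCCCCCc2ccccc2)o1` carries the change (dimethylcarbamoyl in place of 3-methylpyridin-2-yl on an aromatic carbon). Among the compounds with values here, every measured step exchanges one six-membered aromatic ring for another, so no step bears directly on replacing the ring with a group that has no ring; the three steps only show that the group at this position shifts this assay by modest amounts. He therefore expects a rise in the number, read as an 8.0-fold higher number from compound 3 to compound 4 (0.90 log units; beyond the scatter), with wide uncertainty. His estimate for compound 4 in this assay is 120 nM, expected to lie between 30 nM and 500 nM.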

Compound 4, inhibition constant: 2 nM
Compound 4: middle estimate off by 60-fold (1.78 log units), on the high side, outside the stated range (below it).
By their numbers in this assay, from the lowest: compound 4; then compound 3; then compound 2; then compound 1.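

Compound 4 shows that the position next to the ring oxygen does not need a six-membered aromatic ring: in this assay, dimethylcarbamoyl, which has no ring, gives a lower number than all three ring-bearing groups (a 7.5-fold lower number from compound 3 to compound 4 (0.88 log units; beyond the scatter)). The gap widens against the other two groups (a 20-fold lower number from compound 2 to compound 4 (1.30 log units; beyond the scatter); a 55-fold lower number from compound 1 to compound 4 (1.74 log units; beyond the scatter)), and these two steps are the largest among the four compounds, leaving compound 4 with the lowest number. No evidence is available on what lies behind this change.

The compounds shown leave open whether the amide carbonyl or the two methyl groups matter more, a question that a simple unsubstituted amide, a methyl ester or a carboxylic acid in the same place would address. They also leave open whether a bulkier amide, such as the pyrrolidine amide, would keep the number this low.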